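The source may hold more compounds than are shown below. What is called first, only, known or untested is meant among the compounds shown, and "the series" means these compounds.

Measured compounds:
Compound 1 `CCc1cccc(NC(=O)CN2CCN(c3ccc(Cl)cn3)CC2)c1` — 10400 nM
Compound 2 `CCc1cccc(NC(=O)CN2CCN(c3ccccn3)CC2)c1` — 370 nM
Compound 3 `Cc1cccc(NC(=O)CN2CCN(c3cccc4ccccc34)CC2)c1` — 4250 nM

In an assay on cells for antagonist activity at D(4) dopamine receptor (Homo sapiens), read by luminescence and beta-arrestin recruitment, with a stated time of 90 min (a higher number here means a weaker inhibitor, a lower number a stronger inhibitor), compound 1 gives 10400 nM, the highest of the three numbers, so it is the weakest inhibitor of this small group. For the measured compounds named here, the only single-point step among the measured compounds is a 28-fold lower number from compound 1 to compound 2 (1.45 log units; beyond the scatter), a large gain in potency when the chloro group on the aromatic ring of the shared core is taken away. Compound 3 differs in more than one place from compound 1, so the gap between their two numbers cannot be tied to one change; in this assay compound 3 gives 4250 nM.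

Compound 4 `O=C(CN1CCN(c2ccc(Cl)cn2)CC1)Nc1cccnc1` keeps the chloro-bearing part of compound 1 and changes the other end: pyridin-3-yl in place of 3-ethylphenyl on an amide-type nitrogen. Going by the values given here, no measured step touches this position, so the step from compound 1 to compound 2 gives no direct guide, and the change has to be judged from the values alone. With the chloro group still in place, compound 4 is expected to stay near the weak end of the range, with a modest step in either direction possible, a 1.4-fold higher number from compound 1 to compound 4 (0.16 log units; within the scatter). The estimate for compound 4 in this assay is 15000 nM, within a range from 4000 nM to 50000 nM.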

Compound 4, half-maximal inhibitory concentration: 23500 nM
Compound 4: middle estimate off by 1.6-fold (0.19 log units), on the low side; measured number inside the range.
By their numbers in this assay, from the lowest: compound 2; then compound 3; then compound 1; then compound 4.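

In this assay, replacing 3-ethylphenyl with pyridin-3-yl on the amide-type nitrogen gives a 2.3-fold higher number from compound 1 to compound 4 (0.35 log units; beyond the scatter), so this change yields a weaker inhibitor. For the compounds shown here, this is the first single-change reading at this end of the molecule, showing that the group on the amide-type nitrogen also affects the number, although this step is much smaller than the one at the chloro-bearing end, a 28-fold lower number from compound 1 to compound 2 (1.45 log units; beyond the scatter). No independent measurement is available to explain the loss of potency in compound 4.

The swap removes the ethyl chain and also puts a nitrogen into the aromatic ring, so this single step cannot show which of the two alterations matters, and a plain phenyl group on the amide-type nitrogen would help to separate them. From the compounds shown here alone, it also remains open whether pyridin-3-yl would produce a similar step on the core of compound 2, where hydrogen stands in place of chloro.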